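Methoxy placement on the anilino ring in a quinazoline series

The source may report more compounds than this note shows. Statements on the series, on what has been measured and on what is new or still open speak of the compounds shown alone.

Two members of the series have been measured in a functional assay on U2OS cells (Homo sapiens) for cytotoxicity, read by MTT assay, with a stated time of 48 h; on this read-out lower numbers stand for stronger inhibition and higher numbers for weaker inhibition. Compound 1 `Fc1cccc(-c2nc(Nc3ccccc3)c3cc(F)ccc3n2)c1` gives 47600 nM in this assay. Compound 2 `COc1ccc(Nc2nc(-c3cccc(F)c3)nc3ccc(F)cc23)cc1` gives 32300 nM in this assay. Within the data shown here, the only measured step, a 1.5-fold lower number from compound 1 to compound 2 (0.17 log units; within the scatter), adds a methoxy in place of hydrogen on an aromatic carbon and falls within the scatter. Compound 2 therefore stands within the scatter of compound 1, and neither can be called the more active of the two.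

Compound 3 `COc1ccccc1Nc1nc(-c2cccc(F)c2)nc2ccc(F)cc12` is not yet measured. The change from compound 2 is 2-methoxyphenyl in place of 4-methoxyphenyl on a nitrogen on an aromatic ring. Among the measured compounds shown here, no measured step moves a methoxy from one position to another on that ring; the one step available, from compound 1 to compound 2, concerns only the presence of the methoxy and was itself within the scatter. There is thus no basis to expect a step beyond the scatter in this assay, and the expected step is a 1.1-fold higher number from compound 2 to compound 3 (0.05 log units; within the scatter). Compound 3 is estimated to give 36000 nM in this assay, with an expected range from 12000 nM to 100000 nM.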

Compound 3, half-maximal inhibitory concentration: > 50000 nM
Compound 3 gave a limit, no number; the forecaster's own chance of this, stated with the estimate: 10%; middle value at least 1.3-fold (0.14 log units) away from the limit.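

In this assay compound 3 reads as a limit and not as a number: the limit of > 50000 nM in this assay, at which 1 of the 3 values shown sits. Moving the methoxy, with 2-methoxyphenyl in place of 4-methoxyphenyl on a nitrogen on an aromatic ring, gives an at least 1.5-fold higher number from compound 2 to compound 3 (0.18 log units; that floor lies within the scatter); this is a floor only, so the first read on placement at this position allows either a true step beyond the scatter or none. Set against the hydrogen of the unsubstituted phenyl, the 2-methoxyphenyl group gives an at least 1.0-fold higher number from compound 1 to compound 3 (0.02 log units; that floor lies within the scatter), which is again a floor, so neither methoxy placement has yet shown a step beyond the scatter from hydrogen.

From the compounds shown here alone, how far compound 3 lies past its limit remains open, and with it the true size of both steps that end at compound 3. Also open, going by these compounds, is whether a different group on the same phenyl ring, such as an amine or a carboxylic acid in place of the methoxy, would give a step beyond the scatter from compound 1 and bring the series to a lower number in this read-out.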